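Lengthening the imidazole chain of compound 3

The source may report more compounds than this note shows. Statements on the series, on what has been measured and on what is new or still open speak of the compounds shown alone.

In a functional assay on KB cells (Homo sapiens) for antiproliferative activity, read by MTT assay, with a stated time of 48 h (on this read-out lower numbers stand for stronger inhibition and higher numbers for weaker inhibition), compound 3 `Cn1cc(C2=C(c3nn(CCn4ccnc4)c4ncccc34)C(=O)N(c3ccccc3)C2=O)c2ccccc21` reads > 100000 nM, a limit and not a number, and so stands at the limit of > 100000 nM in this assay, at which 2 of the 3 values shown sit. Compound 1 `Cn1cc(C2=C(c3nn(CCCn4cncn4)c4ncccc34)C(=O)N(c3ccccc3)C2=O)c2ccccc21` reads > 100000 nM, also a limit. Compound 2 `Cn1cc(C2=C(c3nn(CCCN4CCCCC4)c4ncccc34)C(=O)N(c3ccccc3)C2=O)c2ccccc21` gives 5600 nM. Compound 4 `Cn1cc(C2=C(c3nn(CCCn4ccnc4)c4ncccc34)C(=O)N(c3ccccc3)C2=O)c2ccccc21` differs from compound 3 by (1H-imidazol-1-yl)methyl in place of 1H-imidazol-1-yl on a saturated chain carbon, two bonds along the chain from an aromatic nitrogen, which turns 2-(1H-imidazol-1-yl)ethyl into 3-(1H-imidazol-1-yl)propyl. Among the compounds with values here, no measured step isolates this change. The nearest are an at least 17-fold lower number from compound 1 to compound 2 (1.25 log units; beyond the scatter) and an at least 17-fold higher number from compound 2 to compound 3 (1.25 log units; beyond the scatter), both large, but each also exchanges the ring group, while a step that the two limits leave unreadable from compound 1 to compound 3 cannot be read. Only a small move towards lower numbers is therefore expected, an at least 2.0-fold lower number from compound 3 to compound 4 (0.30 log units; that floor lies within the scatter), and a further limit remains quite possible. Compound 4 is estimated at 50000 nM, with an expected range of 10000 nM to 200000 nM.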

Compound 4, half-maximal inhibitory concentration: 6800 nM
For compound 4 the middle estimate is 7.4-fold (0.87 log units) above the measured one; measured number below the stated range.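

Lengthening 2-(1H-imidazol-1-yl)ethyl to 3-(1H-imidazol-1-yl)propyl brings an at least 14-fold lower number from compound 3 to compound 4 (1.16 log units; beyond the scatter) and so shows that chain length alone moves this read-out. On the longer chain, an at least 14-fold lower number from compound 1 to compound 4 (1.16 log units; beyond the scatter) separates 1H-imidazol-1-yl from 1H-1,2,4-triazol-1-yl, while a 1.2-fold higher number from compound 2 to compound 4 (0.08 log units; within the scatter) leaves it level with piperidin-1-yl. The readings of compound 1 and compound 3 behind these steps are limits and not numbers: (the limit of > 100000 nM in this assay, at which 2 of the 4 values shown sit).

The compounds shown leave open whether a longer chain, such as 4-(1H-imidazol-1-yl)butyl, would shift the number further. They also leave open whether an open-chain amine such as dimethylamino would match piperidin-1-yl.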